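The source may hold more compounds than are shown below. What is called first, only, known or untested is meant among the compounds shown, and "the series" means these compounds.

Of the compounds shown here, three built on one shared core have been measured in an ADME assay on cells (Hepatocyte, Homo sapiens) for metabolic stability, with a stated time of 30 min; on this read-out lower numbers stand for a less stable compound and higher numbers for a more stable compound. Compound 1 `NC1CCC(CN2CCN(c3cc(=O)c4cc(C(F)(F)F)cc([N+](=O)[O-])c4s3)CC2)CC1` carries an amino group on a saturated ring carbon and gives 83.6% in this assay. Compound 2 `O=C(OC1CCC(CN2CCN(c3cc(=O)c4cc(C(F)(F)F)cc([N+](=O)[O-])c4s3)CC2)CC1)c1cccs1` gives 2.2%, and compound 3 `COc1ccc(C(=O)OC2CCC(CN3CCN(c4cc(=O)c5cc(C(F)(F)F)cc([N+](=O)[O-])c5s4)CC3)CC2)cc1` gives 12.2%. Among these three results compound 3 stands second highest. Its nearest neighbour is compound 2, separated by a number 10 percentage points higher from compound 2 to compound 3 (within the scatter), a gap within the scatter; its furthest is compound 1, with a number 71.4 percentage points lower from compound 1 to compound 3 (beyond the scatter). The step of a number 81.4 percentage points lower from compound 1 to compound 2 (beyond the scatter) is of the same kind: in both large steps the amino group on the saturated ring carbon is replaced, and the read-out drops sharply.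

Compound 4 `Cc1ccc(C(=O)OC2CCC(CN3CCN(c4cc(=O)c5cc(C(F)(F)F)cc([N+](=O)[O-])c5s4)CC3)CC2)cc1` has not yet been measured. It differs from compound 3 only in one place: methyl in place of methoxy on an aromatic carbon. For the measured compounds named here, no measured pair shows exactly this exchange. The closest comparison is the swap of one ring on the carbonyl carbon for another between compound 2 and compound 3, which stayed within the scatter. The large steps belong to a different change and are not expected to recur here. The expected step is therefore a number 2.2 percentage points lower from compound 3 to compound 4 (within the scatter), within the scatter. The estimate for compound 4 in this assay is 10%, with a range from 2% to 25%.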

Compound 4, percent of the compound remaining: 9.7%
The estimate for compound 4 lay 0.3 percentage points above the measured number; the measured number falls inside the stated range.
By their numbers in this assay, from the lowest: compounds 2, 4 and 3 (each within the scatter of the next); then compound 1.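

In this assay, methyl in place of methoxy on this aromatic carbon, para to a large group, takes away the oxygen of the methoxy group and leaves the read-out within the scatter (a number 2.5 percentage points lower from compound 3 to compound 4 (within the scatter)). The new compound also stays within the scatter of the thiophen-2-yl compound (a number 7.5 percentage points higher from compound 2 to compound 4 (within the scatter)), yet it remains far from the amino compound (a number 73.9 percentage points lower from compound 1 to compound 4 (beyond the scatter)), so among these four compounds the size of the gap follows the replacement of the amino group, not the choice among these three groups on the carbonyl carbon. Nothing available here explains why these numbers fall as they do.

Going by these compounds, it remains open whether this para place would tolerate a very different group, such as a carboxylic acid, an amine or a longer chain such as butoxy, with the read-out still staying within the scatter. On these data alone, it is also open whether an amide, with nitrogen in place of the oxygen that joins the carbonyl carbon to the saturated ring, would stand nearer to the amino compound than to the three low-reading compounds.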